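Diethylamino for amino on the chain of compound 3

A few compounds are considered here, and "the series" means these few. Any claim that something is new, unique, unknown or untested is made for them only; others in the source may bear on it.

Of the compounds shown here, three sharing a naphthalenesulfonamide-type core have been measured in an assay on L1.2 cells for binding affinity to C-C chemokine receptor type 8 (Homo sapiens); on this read-out lower numbers stand for stronger inhibition and higher numbers for weaker inhibition. Compound 1, `CCN(CC)S(=O)(=O)c1ccc(NC(=O)c2ccccc2)c2ccccc12`, reaches only the limit of this assay, > 30000 nM, and no number is given for it. Compound 2, `CCOC(=O)N1CCC(NS(=O)(=O)c2ccc(OC(=O)c3ccccc3)c3ccccc23)CC1`, gives 16.4 nM in this assay. Compound 3, `Cc1ccccc1C(=O)Nc1ccc(S(=O)(=O)NC2CCN(C(=O)CCCN)CC2)c2ccccc12`, gives 1.6 nM, the lowest of the two numbers reported; its nearest neighbour is compound 2, whose value lies well beyond the usual scatter above it, so compound 3 stands apart from compound 2 on these numbers. Going by the values given here, compound 1 sits at the limit described as the limit of > 30000 nM in this assay, at which 1 of the 3 values shown sits, and no step from it to the others can be read.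

Compound 4, `CCN(CC)CCCC(=O)N1CCC(NS(=O)(=O)c2ccc(NC(=O)c3ccccc3C)c3ccccc23)CC1`, has not yet been measured in this assay. It differs from compound 3 in one place: diethylamino in place of amino on a saturated chain carbon, three bonds along the chain from a carbonyl carbon. The change sits on a saturated chain carbon, three bonds along the chain from a carbonyl carbon, and keeps the hydrogen-bond acceptor count while the donor is lost. With no measured step of this kind among the compounds shown, the expected change from compound 3 in this assay is small, within or near the scatter: a 1.1-fold lower number from compound 3 to compound 4 (0.03 log units; within the scatter). Compound 4 is therefore estimated to give 1.5 nM in this assay, in a range from 0.4 nM to 6 nM.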

Compound 4, inhibition constant: 567 nM
Estimate against measurement, compound 4: 380-fold (2.58 log units) below; measured number above the stated range.
By their numbers in this assay, from the lowest: compound 3; then compound 2; then compound 4. At a limit, above all of these: compound 1.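

In this assay, putting diethylamino in place of amino on a saturated chain carbon, three bonds along the chain from a carbonyl carbon, gives a 350-fold higher number from compound 3 to compound 4 (2.55 log units; beyond the scatter), the first step shown between compounds that differ in one place. This shows that the end of this chain is not a place where any amine serves equally: the read-out responds strongly when the amino group, with its hydrogen-bond donor, gives way to diethylamino, which has none and carries more heavy atoms. Nothing measured among these compounds bears on the cause of this step.

The single step changes the donor count and the number of heavy atoms together, so the compounds shown cannot separate the two, and a methylamino or dimethylamino group on the same chain would be needed to tell how the loss builds up. Also open, on these data alone, is how a shorter or longer chain carrying the amino group, or a carboxylic acid at the chain end, would read in this assay.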